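A Methyl Added to the Ester Chain

A few compounds are considered here, and "the series" means these few. Any claim that something is new, unique, unknown or untested is made for them only; others in the source may bear on it.

compound 1, `COC(=O)C(O)Cn1cnc2c(N)ncnc21`, in a functional assay on Vero cells (Chlorocebus sabaeus) for cytotoxicity; a lower number here means that less compound is tolerated, a higher number that more compound is tolerated: > 400 ug/mL, a limit of the assay
compound 2, `CCCOC(=O)C(O)Cn1cnc2c(N)ncnc21`, in this assay: > 400 ug/mL, a limit of the assay

Both measured values are limits rather than numbers, as the limit of > 400 ug/mL in this assay, at which 2 of the 2 values shown sit, records. Compound 2 therefore stands at the top of what this assay can report, and nothing separates it from compound 1 on the numbers shown. Going by the values given here, the only measured step, a step that the two limits leave unreadable from compound 1 to compound 2, is the change from compound 1 to compound 2; because both of its ends are limits, its size cannot be read.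

Compound 3, `CCC(C)OC(=O)C(O)Cn1cnc2c(N)ncnc21`, differs from compound 2 in one place: methyl in place of hydrogen on a saturated chain carbon bound to an oxygen next to a carbonyl group and a saturated chain carbon. Among the compounds with values here, the one measured step that bears on the ester chain is unreadable, so no measured step gives a size or a direction for this change. The expectation for compound 3 is thus a step of no size beyond the scatter, a number no higher from compound 2 to compound 3 (the limit leaves the size open), and the estimate for compound 3 in this assay is 400 ug/mL, between 200 ug/mL and 800 ug/mL, most likely again reported only as a limit.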

Compound 3, minimum cytotoxic concentration: > 400 ug/mL
Compound 3: no number, only a limit (the forecaster's own chance of this, stated with the estimate: 85%); the middle value sits exactly at the limit.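

Compound 3, like compound 1 and compound 2, returns only a limit in this assay, so no new step can be read among the three: the limit of > 400 ug/mL in this assay, at which 3 of the 3 values shown sit. The compounds shown leave open whether any ester chain on the shared core, from methyl to sec-butyl, would give a minimum cytotoxic concentration reportable as a number.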